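A few compounds are considered here, and "the series" means these few. Any claim that something is new, unique, unknown or untested is made for them only; others in the source may bear on it.

Measured compounds:
Compound 1 `CC(=O)Nc1nc(-c2cccc(NS(=O)(=O)c3ccc(C#C[Si](C)(C)C)cc3)c2)cs1` gives 4.2% in a functional assay on A-375 cells (Homo sapiens) for antiproliferative activity, read by trypan blue exclusion, with a stated time of 48 h, tested at 5 uM; a higher number here means a weaker effect of the compound at the concentration tested, a lower number a stronger effect.
Compound 2 `CC(=O)Nc1nc(-c2cccc(NS(=O)(=O)c3cccc(C#CCO)c3)c2)cs1` gives 66.2% in this assay.

Compound 1 stands lowest of the two numbers recorded, which in this assay marks the stronger effect. Its nearest neighbour is compound 2, whose value lies far above it, well beyond the usual scatter of this assay. Among the measured compounds shown here, compound 2 differs from compound 1 in more than one place, so the two values show only that the pair spans a wide range; no single step between measured compounds can be isolated from them.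

Compound 3 `CCCCCCc1ccc(S(=O)(=O)Nc2cccc(-c3csc(NC(C)=O)n3)c2)cc1` has not been measured in this assay. It differs from compound 1 in one place: a group of 6 heavy atoms (6 carbon; no ring) in place of a group of 6 heavy atoms (5 carbon, 1 silicon; no ring), on an aromatic carbon. The hexyl group matches the departing group in heavy-atom count and in lacking a ring and any donor or acceptor, but it gives up the triple bond and the silicon.

For the measured compounds named here, with no measured step to lean on, the expectation for compound 3 is an estimated rise beyond the scatter, a number 17.8 percentage points higher from compound 1 to compound 3 (beyond the scatter), toward a weaker effect. Compound 3 is estimated at 22%, within a range of 4% to 60%.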

Compound 3, a percentage reported as activity, at one concentration (the size of the read-out at that concentration, not a potency): < 1%
Compound 3 was reported as a limit; the forecaster's own chance of this, stated with the estimate: 0%; middle value at least 21 percentage points from the limit.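

The value of compound 3 in this assay, < 1%, is a limit of the assay and not a number: the limit of < 1% in this assay, at which 1 of the 3 values shown sits. At this aromatic carbon, para to a large group, putting hexyl in place of the silicon-bearing group with its triple bond gives a number at least 3.2 percentage points lower from compound 1 to compound 3 (that floor lies within the scatter). That figure is only a floor on the size of the step. This first single-place step shows that neither the triple bond nor the silicon is needed at this position to keep the strong effect seen with compound 1, since a plain hexyl chain of the same heavy-atom count does not weaken it.

The compounds shown leave open how short this chain can become, or whether an amine or a carboxylic acid at the end of the hexyl chain would keep the effect. Compound 2 differs from both compound 1 and compound 3 in more than one place, so its much weaker effect cannot be assigned to any one of those differences.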